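Cinnamate glycolamide series: aryl amide substituent notes

A few compounds are considered here, and "the series" means these few. Any claim that something is new, unique, unknown or untested is made for them only; others in the source may bear on it.

Compound 1 `COCOc1cc(/C=C/C(=O)OCC(=O)Nc2ccc(OC)cc2)ccc1OCc1ccccc1` and compound 2 `COCOc1cc(/C=C/C(=O)OCC(=O)Nc2ccc(Cl)cc2)ccc1OCc1ccccc1` share one core, while compound 3 `COc1ccc(NC(=O)COC(=O)/C=C/c2cc(OC)c(OCc3ccc(Cl)c(Cl)c3)c(OC)c2)cc1` and the unmeasured compound 4 `COc1cc(/C=C/C(=O)OCC(=O)Nc2ccc(Cl)cc2)cc(OC)c1OCc1ccc(Cl)c(Cl)c1` share a second core; the difference between the two cores is not broken down here. In a functional assay on CNE cells (Homo sapiens) for cytotoxicity, read by MTT assay, with a stated time of 72 h (on this read-out higher numbers stand for weaker inhibition and lower numbers for stronger inhibition), compound 1 reports only a limit of the assay, > 200000 nM. Compound 2 likewise reports only a limit in this assay, > 200000 nM. For compound 3 this assay again gives only a limit, > 200000 nM. The change from compound 1 to compound 2 is chloro in place of methoxy on an aromatic carbon; the step that the two limits leave unreadable from compound 1 to compound 2 stays unreadable because of the limit of > 200000 nM in this assay, at which 3 of the 3 values shown sit. The change from compound 3 to compound 4 is chloro in place of methoxy on an aromatic carbon, the same change made on the second core. The step that the limit leaves unreadable from compound 3 to compound 4 is expected to remain unreadable in this assay in the same way. This expectation rests on a step that the two limits leave unreadable from compound 1 to compound 2 and on (the limit of > 200000 nM in this assay, at which 3 of the 3 values shown sit). Compound 4 is therefore estimated at 300000 nM in this assay, between 100000 nM and 1000000 nM, and is expected most likely to be reported again only as a limit.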

Compound 4, half-maximal inhibitory concentration: > 200000 nM
Compound 4 gave a limit, no number; the forecaster's own chance of this, stated with the estimate: 85%; the middle value does not contradict the limit.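

In this assay compound 4 gives only a limit, > 200000 nM, so the step from compound 3 to compound 4 cannot be read, and neither can the one from compound 1 to compound 2: the limit of > 200000 nM in this assay, at which 4 of the 4 values shown sit.

Going by these compounds, whether methoxy or chloro on the aryl amide, on either core, differs at all in this assay stays open.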